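Working notes: methyl on the phenyl of compound 1

The source may hold more compounds than are shown below. What is called first, only, known or untested is meant among the compounds shown, and "the series" means these compounds.

compound 1 `CCOC(=O)[C@@H]1C(=O)N(Cc2ccccc2)C[C@@H](ON2C(C)(C)CCCC2(C)C)[C@H]1c1ccccc1` — a physicochemical assay, with a stated time of 60 min; on this read-out lower numbers stand for stronger inhibition and higher numbers for weaker inhibition: 12300 nM
compound 2 `CCOC(=O)[C@@H]1C(=O)N(Cc2ccccc2)C[C@@H](O)[C@H]1c1ccccc1` — this assay: > 100000 nM, a limit
compound 3 `CCOC(=O)[C@@H]1C(=O)N(Cc2ccccc2)CC[C@H]1c1ccccc1` — this assay: > 100000 nM, a limit

Among the measured compounds shown here, compound 1 holds the only number in this assay; the other two values stop at the limit of > 100000 nM in this assay, at which 2 of the 3 values shown sit. Both measured steps concern the oxygen substituent on the saturated ring: an at least 8.1-fold higher number from compound 1 to compound 2 (0.91 log units; beyond the scatter) and an at least 8.1-fold higher number from compound 1 to compound 3 (0.91 log units; beyond the scatter), while a step that the two limits leave unreadable from compound 2 to compound 3. Compound 4 `CCOC(=O)[C@@H]1C(=O)N(Cc2ccccc2)C[C@@H](ON2C(C)(C)CCCC2(C)C)[C@H]1c1ccc(C)cc1` differs from compound 1 by methyl in place of hydrogen on an aromatic carbon. For the measured compounds named here, no measured step touches the aromatic ring, so none of them bears on this change. For compound 4 the expectation is therefore a step of a 1.2-fold lower number from compound 1 to compound 4 (0.09 log units; within the scatter), none beyond the scatter. The estimate for compound 4 is 10000 nM, with a range from 3500 nM to 30000 nM.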

Compound 4, half-maximal inhibitory concentration: 98400 nM
Estimate against measurement, compound 4: 9.8-fold (0.99 log units) below, and the stated range ends below it.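

Among the compounds shown here, the aromatic ring, which no earlier step touched, proves responsive in this assay: 4-methylphenyl in place of phenyl gives an 8.0-fold higher number from compound 1 to compound 4 (0.90 log units; beyond the scatter). Activity in this series therefore depends on this ring as well as on the oxygen substituent, and a single methyl para to a large group is enough to change the read-out. Compounds 2 and 3 remain limits, not numbers: the limit of > 100000 nM in this assay, at which 2 of the 4 values shown sit.

Whether this loss is specific to methyl remains open, as fluoro, methoxy and a carboxylic acid at this place are not among the compounds shown. Also open, from the compounds shown here alone, is how other positions on the ring respond.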